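The source may hold more compounds than are shown below. What is called first, only, known or untested is meant among the compounds shown, and "the series" means these compounds.

Compound 1 `CC(C(=O)N1CCN(c2ccccc2F)CC1)N1C(=O)CCC1=O`: 25%
Compound 2 `Cc1cccc(N2CCN(C(=O)C(C)N3C(=O)CCC3=O)CC2)c1`: 0%

Both compounds share one core and differ only in the group on an amine nitrogen in a ring. In a functional assay on the whole organism (strain Swiss) with Mus musculus as the target, in the maximal electroshock model, with a stated time of 2 h, at a dose of 300 mg/kg by the intraperitoneal route (a lower number here means a weaker effect, a higher number a stronger effect of the compound at the dose given), compound 1 gives 25%, whereas compound 2 gives 0%. Compound 2 thus stands lowest of the two numbers; its nearest neighbour is compound 1, and the step of a number 25 percentage points lower from compound 1 to compound 2 (beyond the scatter) lies beyond the scatter.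

Compound 3 `CC(C(=O)N1CCN(c2ccccc2Cl)CC1)N1C(=O)CCC1=O` has not been measured. It differs from compound 2 by 2-chlorophenyl in place of 3-methylphenyl on an amine nitrogen in a ring. Among the compounds with values here, the single step that bears on this change is a number 25 percentage points lower from compound 1 to compound 2 (beyond the scatter), which accompanied 3-methylphenyl in place of 2-fluorophenyl. The change to compound 3 removes the 3-methylphenyl again and brings the structure nearer to compound 1, which carries 2-fluorophenyl at the same place. Within the data shown here, a rise in this assay of about the size seen for compound 1 is therefore expected, though the data give only one pair to rest on. For compound 3 a value of 25% is estimated, with a range from 0% to 50%. This estimate corresponds to an expected step of a number 25 percentage points higher from compound 2 to compound 3 (beyond the scatter).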

Compound 3, a percentage reported as activity, at one dose (the size of the read-out at that dose, not a potency): 0%
The estimate for compound 3 lay 25 percentage points above the measured number; the range from low to high includes it.
By their numbers in this assay, from the lowest: compounds 2 and 3 (each within the scatter of the next); then compound 1.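

In this assay, 2-chlorophenyl in place of 3-methylphenyl on an amine nitrogen in a ring gives no change at the digits printed from compound 2 to compound 3 (within the scatter), so taking away the 3-methylphenyl does not by itself bring back the read-out of compound 1. Chloro in place of fluoro on an aromatic carbon gives a number 25 percentage points lower from compound 1 to compound 3 (beyond the scatter), which shows that this position responds to the exchange of one halogen for another and that a halogen on the phenyl ring is not enough for a read-out in this series; of the three compounds, only the one with 2-fluorophenyl gives a number above zero. No measured property accompanies these numbers, and the data offer no explanation of this result.

Still open, going by these compounds, is whether the read-out of compound 1 is particular to fluoro or would also appear with an unsubstituted phenyl, or with a methoxy group or a nitrile on the phenyl ring. With one dose and one time point, the compounds shown also leave open whether compound 2 and compound 3 would separate under other conditions.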